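From compound 2 to compound 3: a chain on the nitrogen

This account rests on a few compounds, and the source may have more. Where it says the series, first, only, none or still open, it means among the compounds named here.

Going by the values given here, in a functional assay on KB cells (Homo sapiens) for antiproliferative activity, read by MTT assay, with a stated time of 48 h (a lower number here means a stronger inhibitor, a higher number a weaker inhibitor), compound 2 `Cn1cc(C2=C(c3n[nH]c4ncccc34)C(=O)NC2=O)c2ccccc21` gives 62000 nM, the only actual number among the values so far. Compound 1 `CN(C)CCCn1nc(C2=C(c3cn(C)c4ccccc34)C(=O)NC2=O)c2cccnc21` reads > 100000 nM, which is a limit of the assay and not a number. Compound 1 carries 3-(dimethylamino)propyl on the aromatic nitrogen where compound 2 has hydrogen. Among the compounds with values here, the single measured step, an at least 1.6-fold lower number from compound 1 to compound 2 (0.20 log units; that floor lies within the scatter), is the one guide to a chain at this place, and it offers only a floor.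

The change to compound 3 `Cn1cc(C2=C(c3nn(CCCO)c4ncccc34)C(=O)NC2=O)c2ccccc21` is 3-hydroxypropyl in place of hydrogen on an aromatic nitrogen. Resting on compound 1 and the step of an at least 1.6-fold lower number from compound 1 to compound 2 (0.20 log units; that floor lies within the scatter), a small move toward a higher number is expected in this assay, with a real chance of another limit. The expected change is a 1.4-fold higher number from compound 2 to compound 3 (0.14 log units; within the scatter), which stays within the scatter. For compound 3 the estimated value is 85000 nM, with an expected range of 40000 nM to 170000 nM.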

Compound 3, half-maximal inhibitory concentration: > 100000 nM
Compound 3: a limit, no number (the forecaster's own chance of this, stated with the estimate: 45%); middle value at least 1.1-fold (0.07 log units) away from the limit.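

In this assay compound 3 gives > 100000 nM, which is a limit of the assay and not a number. Until now the only chain on this aromatic nitrogen was 3-(dimethylamino)propyl; 3-hydroxypropyl gives an at least 1.6-fold higher number from compound 2 to compound 3 (0.20 log units; that floor lies within the scatter), so a chain ending in hydroxy also offers only a floor, and that floor does not pass the scatter. The two chains cannot be ranked against each other, and the step between them cannot be read, since each compound carrying one sits at the same limit: the limit of > 100000 nM in this assay, at which 2 of the 3 values shown sit.

Going by these compounds, how a methyl group, a longer chain or a chain ending in a carboxylic acid would read on this nitrogen stays open. Also open, on these data alone, is whether any group here can give a lower number than compound 2 gives with 62000 nM.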